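An isopropoxy step on compound 2

This account rests on a few compounds, and the source may have more. Where it says the series, first, only, none or still open, it means among the compounds named here.

In a functional assay on brain (Rattus norvegicus, strain Wistar) for inhibition (a lower number here means a stronger inhibitor, a higher number a weaker inhibitor), compound 2 `Cc1[nH]c(=O)n(C2CCCCC2)c1-c1ccccc1` gives 47600 nM. Compound 3 `CCCCc1ccc(-c2c(C)[nH]c(=O)n2C2CCCCC2)cc1` gives 27100 nM, and the two values lie within the scatter of each other, as a 1.8-fold lower number from compound 2 to compound 3 (0.24 log units; within the scatter) shows. Compound 1 `CCCCn1c(-c2ccccc2)c(C)[nH]c1=O` gives > 100000 nM, which is a limit of the assay and not a number. Compound 2 therefore has one measured neighbour with a number and one with only a limit.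

Compound 4 `Cc1[nH]c(=O)n(C2CCCCC2)c1-c1cccc(OC(C)C)c1` carries isopropoxy in place of hydrogen on an aromatic carbon, on the ring that holds the change in compound 3 (isopropoxy in place of hydrogen on an aromatic carbon). The measured change on the nitrogen, an at least 2.1-fold lower number from compound 1 to compound 2 (0.32 log units; beyond the scatter), lies at a different place and says little about this one. The closest guide is compound 3, also a replacement of hydrogen on an aromatic carbon, with a 1.8-fold lower number from compound 2 to compound 3 (0.24 log units; within the scatter). That single small step gives no ground to expect a large change, so only a modest shift towards a lower number is expected, and it may not clear the scatter. The expected change is a 1.5-fold lower number from compound 2 to compound 4 (0.17 log units; within the scatter). For compound 4 the estimated value is 32000 nM, with an expected range from 11000 nM to 90000 nM.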

Compound 4, half-maximal inhibitory concentration: 10400 nM
Compound 4: the middle estimate sits 3.1-fold (0.49 log units) above what was measured, and the stated range ends above it.
By their numbers in this assay, from the lowest: compound 4; then compounds 3 and 2 (each within the scatter of the next). At a limit, above all of these: compound 1.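

In this assay, isopropoxy on an aromatic carbon of the six-membered aromatic ring of carbon only, meta to a large group, gives a 4.6-fold lower number from compound 2 to compound 4 (0.66 log units; beyond the scatter). The earlier replacement of hydrogen on this ring, a 1.8-fold lower number from compound 2 to compound 3 (0.24 log units; within the scatter), stayed inside the scatter, so compound 4 is the first of the compounds shown in which a group on this ring moves the number by more than the scatter. The group that enters brings 4 heavy atoms, among them 1 oxygen, and no ring, so a single ether-linked group of this size is enough for a step that can be read on this ring.

The compounds shown do not separate the part played by the oxygen from that of the carbon chain or from that of the place on the ring, and compound 3 and compound 4 differ in more than one place, so they cannot settle it. How a methoxy group, a hydroxyl group or an amine would read at this same place stays open, and the scale of this assay has a ceiling at its weak end: the limit of > 100000 nM in this assay, at which 1 of the 4 values shown sits.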